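Swapping chloro for bromo on the shared core

The source may hold more compounds than are shown below. What is called first, only, known or untested is meant among the compounds shown, and "the series" means these compounds.

Among the measured compounds shown here, in a functional assay on PC-3 cells (Homo sapiens) for cytotoxicity, read by MTT assay, with a stated time of 72 h (a lower number here means a stronger inhibitor, a higher number a weaker inhibitor), compound 2 `O=C(c1ccccc1)c1sc(N2CCCCC2)nc1Cl` gives 69000 nM, the only actual number so far. Compound 1 `O=C(c1ccccc1)c1sc(N2CCCC2)nc1Br` is reported only as a limit, > 100000 nM. Compound 3 `O=C(c1ccccc1)c1sc(N2CCCCC2)nc1Br` has yet to be measured; it carries bromo in place of chloro on an aromatic carbon, next to the ring nitrogen. For the measured compounds named here, no step between measured compounds offers a guide, so the change expected in this assay, a 1.1-fold lower number from compound 2 to compound 3 (0.03 log units; within the scatter), stays within the scatter, with no direction expected. Compound 3 is estimated at 65000 nM, with an expected range of 30000 nM to 100000 nM.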

Compound 3, half-maximal inhibitory concentration: 62000 nM
Compound 3: middle estimate off by 1.0-fold (0.02 log units), on the high side; measured number inside the range.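

At this carbon, next to the ring nitrogen, bromo in place of chloro gives in this assay a 1.1-fold lower number from compound 2 to compound 3 (0.05 log units; within the scatter), so the two halogens cannot be told apart here. With bromo held fixed, piperidin-1-yl in place of pyrrolidin-1-yl gives an at least 1.6-fold lower number from compound 1 to compound 3 (0.20 log units; that floor lies within the scatter), a floor only, which cannot show whether that swap matters. Compound 1 is reported only as a limit: the limit of > 100000 nM in this assay, at which 1 of the 3 values shown sits. The compounds shown leave open whether a nitrile or an amine at this carbon, or a morpholine in place of piperidin-1-yl, would move the number beyond the scatter.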